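The source may hold more compounds than are shown below. What is called first, only, known or untested is meant among the compounds shown, and "the series" means these compounds.

Compound 2, with the structure `CC1=C(C(=O)Nc2ccc([N+](=O)[O-])cc2)C(c2ccc(Br)cc2)N=C(SCc2ccccc2Cl)N1`, is the starting point here. In a functional assay on the whole organism (artery, strain albino) with Rattus norvegicus as the target, with a stated time of 15 min, at a dose of 10 mg/kg by the oral route (a higher number here means more inhibition at the dose given (going by the name of the read-out), a lower number less inhibition), compound 2 gives 1.5%. For the measured compounds named here, only one other compound has been measured alongside it: compound 1, with the structure `CC1=C(C(=O)Nc2ccc([N+](=O)[O-])cc2)C(c2ccc(Br)cc2)N=C(SCc2ccccc2)N1`, which in this assay gives 2.1%. Going by the values given here, the single measured step, a number 0.6 percentage points lower from compound 1 to compound 2 (within the scatter), falls within the scatter, so the two compounds cannot be told apart on these numbers, and compound 2 stands level with compound 1 rather than apart from it.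

Compound 3, with the structure `CC1=C(C(=O)Nc2ccc([N+](=O)[O-])cc2)C(c2ccc(Br)cc2)N=C(SCc2cccc(Cl)c2)N1`, differs from compound 2 by 3-chlorophenyl in place of 2-chlorophenyl on a saturated chain carbon bound to a sulfur. Among the compounds with values here, no measured step moves a chlorine from one place on this ring to another, so nothing measured speaks directly to this change; the one step available, a number 0.6 percentage points lower from compound 1 to compound 2 (within the scatter), was within the scatter. On that basis the expectation is a step of a number 0.5 percentage points higher from compound 2 to compound 3 (within the scatter), no bigger than the scatter. Compound 3 is therefore estimated at 2%, within a range from 0% to 10%.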

Compound 3, a percentage reported as inhibition, in the whole organism at one dose (the size of the read-out at that dose, not a potency): 2.1%
The estimate for compound 3 lay 0.1 percentage points below the measured number; the measured number falls inside the stated range.
By their numbers in this assay, from the lowest: compounds 2, 1 and 3 (each within the scatter of the next).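

In this assay, putting 3-chlorophenyl in place of 2-chlorophenyl on a saturated chain carbon bound to a sulfur gives a number 0.6 percentage points higher from compound 2 to compound 3 (within the scatter), while the chloro group in its 3-chlorobenzyl form gives no change at the digits printed from compound 1 to compound 3 (within the scatter). Two chlorine placings on this ring can now be compared with the chlorine-free benzyl group of compound 1, and the three compounds cannot be told apart on these numbers. Nothing measured here offers a reason for this flat result.

From the compounds shown here alone, it remains open whether this position would respond to a different group on the ring, such as an amine or a carboxylic acid, or to a longer chain in place of benzyl. Going by these compounds, the rest of the core is the same in all three compounds, so what those parts contribute in this assay also remains open.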